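A few compounds are considered here, and "the series" means these few. Any claim that something is new, unique, unknown or untested is made for them only; others in the source may bear on it.

Measured so far in a functional assay on the whole organism for inhibition, with Rattus norvegicus as the target, at a dose of 20 mg/kg by the oral route; on this read-out lower numbers stand for less inhibition and higher numbers for more inhibition at the one dose given (going by the name of the read-out):
compound 1 `CNC(=O)/C=C1\CCc2c(C)cc(F)cc21` gives 77%;
compound 2 `CNC(=O)/C=C1\CCc2cc(Cl)cc(Cl)c21` gives 22%;
compound 3 `NC(=O)/C=C1\CCc2cc(Cl)cc(Cl)c21` gives 79%.

Compound 4 `Cc1cc(F)cc2c1CC/C2=C\C(N)=O` has not yet been measured in this assay. It comes from compound 1 by a single change, (hydrogen in place of methyl on an amide-type nitrogen), and the same change links compound 2 to compound 3, (hydrogen in place of methyl on an amide-type nitrogen); the place of the change is described in the same words for both pairs, so it is the same change on two cores. The difference between the two cores themselves is not broken down here. In this assay the change already made gave a number 57 percentage points higher from compound 2 to compound 3 (beyond the scatter). A far smaller step is expected this time, a number 8 percentage points higher from compound 1 to compound 4 (within the scatter). This rests on compound 1 already showing 77%, a number that is already high and so leaves little room for it to go higher, whereas compound 2 started from a low number before its step of a number 57 percentage points higher from compound 2 to compound 3 (beyond the scatter). Compound 4 is therefore estimated at 85%, between 70% and 97%.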

Compound 4, a percentage reported as inhibition, in the whole organism at one dose (the size of the read-out at that dose, not a potency): 92%
Estimate against measurement, compound 4: 7 percentage points below, within the range that was stated.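

In this assay putting hydrogen in place of methyl on the amide-type nitrogen gives a number 15 percentage points higher from compound 1 to compound 4 (beyond the scatter) and so goes the same way as on the other core. The direction of the change carries over between these two cores, but its size does not: the same change on two cores in this assay, a number 57 percentage points higher (beyond the scatter) from compound 2 to compound 3 and a number 15 percentage points higher (beyond the scatter) from compound 1 to compound 4, 42 percentage points apart, beyond the scatter of two such steps. This shows that the gain from the change cannot simply be copied from one core to another, but it does not show what makes the two steps differ or how the change would behave on a third core.

The compounds shown carry only methyl or hydrogen on this nitrogen. As far as these compounds go, a longer chain such as ethyl, or a ring such as cyclopropyl, in the same place remains open.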